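The source may report more compounds than this note shows. Statements on the series, on what has been measured and on what is new or still open speak of the compounds shown alone.

Working notes on the series built on the core of compound 1 `COc1ccc(/C=C\c2cc(OC)c(OC)c(OC)c2)cc1OCc1ccc(C=O)cc1`, which in a functional assay on MC-38 cells (Mus musculus) for antiproliferative activity, read by CCK-8 assay, with a stated time of 48 h (a lower number here means a stronger inhibitor, a higher number a weaker inhibitor), gives 900 nM. Compound 2 `COc1ccc(/C=C\c2cc(OC)c(OC)c(OC)c2)cc1OCc1ccc(CN2C[C@H](O)C[C@@H]2C(=O)O)cc1` in this assay reaches only the assay limit, > 10000 nM. Compound 3 `COc1ccc(/C=C\c2cc(OC)c(OC)c(OC)c2)cc1OCc1ccc(CN2CCCC[C@@H]2C(=O)O)cc1` likewise sits at the limit, > 10000 nM. The step of an at least 11-fold higher number from compound 1 to compound 2 (1.04 log units; beyond the scatter) and the step of an at least 11-fold higher number from compound 1 to compound 3 (1.04 log units; beyond the scatter) both end at the same ceiling, (the limit of > 10000 nM in this assay, at which 2 of the 3 values shown sit), so the step that the two limits leave unreadable from compound 2 to compound 3. Compound 4 `COc1ccc(/C=C\c2cc(OC)c(OC)c(OC)c2)cc1OCc1ccc(CN2CCCCC2C(=O)O)cc1` differs from compound 2 by 2-carboxypiperidin-1-yl in place of 2-carboxy-4-hydroxypyrrolidin-1-yl on a saturated chain carbon bound to an aromatic carbon. Compound 3 carries this same change with defined stereochemistry and gives > 10000 nM, a limit, so for compound 4, the same skeleton without defined stereochemistry, no readable number is expected either. Compound 4 is expected at 12000 nM (range 3000 nM to 40000 nM) in this assay, meaning an expected step that the limit leaves unreadable from compound 2 to compound 4.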

Compound 4, half-maximal inhibitory concentration: 5400 nM
The estimate for compound 4 lay 2.2-fold (0.35 log units) above the measured number; low and high end bracket the measured number.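

With (2-carboxypiperidin-1-yl)methyl in place of formyl on an aromatic carbon, this assay now gives a readable number for this change, and the loss has a size: a 6.0-fold higher number from compound 1 to compound 4 (0.78 log units; beyond the scatter). The floors an at least 1.8-fold lower number from compound 2 to compound 4 (0.26 log units; that floor lies within the scatter) and an at least 1.8-fold lower number from compound 3 to compound 4 (0.26 log units; that floor lies within the scatter) both lie within the scatter, so neither step establishes a real gain.

Any role of configuration at the saturated ring carbon remains unresolved because of this difference in drawing: the fact that one of compounds 3 and 4 is drawn with a defined configuration and the other without, at the place where they differ Also open is whether a methyl ester or an amide in place of the carboxylic acid would recover the number of compound 1, 900 nM.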